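Aryl variation on the pyrazole of the shared core

The compounds below may be only part of what the source reports. "The series", "measured", "known", "first", "only" and "open" are said of these compounds alone.

Compound 2 `Cc1nn(-c2nc(-c3ccc(Cl)c(Cl)c3)c(SC(C)C)s2)c(C(=O)O)c1-c1cccc(C(F)(F)F)c1` is the higher of the two numbers measured in a functional assay on BJAB cells (Homo sapiens) for antiproliferative activity, with a stated time of 4 days (a higher number here means that more compound is needed for the effect, a lower number that less compound is needed), where compound 2 gives 22000 nM and compound 1 `Cc1nn(-c2nc(-c3ccc(Cl)c(Cl)c3)c(SC(C)C)s2)c(C(=O)O)c1-c1ccc(Cl)cc1` gives 2500 nM. Within the data shown here, the one measured step, an 8.8-fold higher number from compound 1 to compound 2 (0.94 log units; beyond the scatter), shows that exchanging the aryl group on this carbon moves the number well beyond the scatter. Compound 3 `CNc1cc(-c2c(C)nn(-c3nc(-c4ccc(Cl)c(Cl)c4)c(SC(C)C)s3)c2C(=O)O)ccn1` carries the change (2-(methylamino)pyridin-4-yl in place of 3-(trifluoromethyl)phenyl on an aromatic carbon). Among the measured compounds shown here, no measured step covers this group, so only the size of the aryl effect is known. A step of comparable size is expected, more likely downward toward compound 1 than upward: a 4.4-fold lower number from compound 2 to compound 3 (0.64 log units; beyond the scatter). The estimated value for compound 3 is 5000 nM, within 1000 nM to 25000 nM.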

Compound 3, half-maximal effective concentration: 18000 nM
For compound 3 the middle estimate is 3.6-fold (0.56 log units) below the measured one, and the stated range covers the measured number.
By their numbers in this assay, from the lowest: compound 1; then compounds 3 and 2 (each within the scatter of the next).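

In this assay, 2-(methylamino)pyridin-4-yl and 3-(trifluoromethyl)phenyl on this aromatic carbon are not separated, with a 1.2-fold lower number from compound 2 to compound 3 (0.09 log units; within the scatter). A ring nitrogen and a methylamino group therefore leave compound 3 level with compound 2, while a 7.2-fold higher number from compound 1 to compound 3 (0.86 log units; beyond the scatter) sets the 4-chlorophenyl of compound 1 apart from both other groups. Nothing available bears on the reason for this result.

Still open, as far as these compounds go, is whether the chlorine of compound 1 matters in itself, which unsubstituted phenyl or 3-chlorophenyl on this carbon would test. Also open, from the compounds shown here alone, is whether 2-aminopyridin-4-yl would stay level with compound 3.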